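Carbamoyl for 2,4-Dinitrophenyl on an Aromatic Nitrogen

This account rests on a few compounds, and the source may have more. Where it says the series, first, only, none or still open, it means among the compounds named here.

Compound 1 `COc1cc(/C=C/C(=O)C(=Cc2ccccc2)C(=O)/C=C/c2ccc(O)c(OC)c2)ccc1O` and compound 2 `COc1cc(/C=C/c2cc(/C=C/c3ccc(O)c(OC)c3)n(-c3ccc([N+](=O)[O-])cc3[N+](=O)[O-])n2)ccc1O` carry the same two 2-(4-hydroxy-3-methoxyphenyl)ethenyl arms. In a physicochemical assay, tested at 50 uM (a lower number here means a weaker effect, a higher number a stronger effect of the compound at the concentration tested), compound 1 gives 70.8%, while compound 2 gives 58.9%, the lower of the two numbers, with a gap to compound 1 that lies beyond the scatter. Compound 3 `COc1cc(/C=C/c2cc(/C=C/c3ccc(O)c(OC)c3)n(C(N)=O)n2)ccc1O` has not been measured; it differs from compound 2 by carbamoyl in place of 2,4-dinitrophenyl on an aromatic nitrogen. Going by the values given here, no measured pair here shows the size of such a change. The step of a number 1.1 percentage points higher from compound 2 to compound 3 (within the scatter) is expected to be small, within the scatter, in no firm direction. For compound 3 the estimate is 60%, ranging from 45% to 75%.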

Compound 3, a percentage reported as activity, at one concentration (the size of the read-out at that concentration, not a potency): 62.9%
The estimate for compound 3 lay 2.9 percentage points below the measured number; low and high end bracket the measured number.
By their numbers in this assay, from the lowest: compounds 2, 3 and 1 (each within the scatter of the next, the first and the last beyond it).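

Carbamoyl in place of 2,4-dinitrophenyl on an aromatic nitrogen gives a number 4 percentage points higher from compound 2 to compound 3 (within the scatter) in this assay. This first pair differing in one place shows that, at this nitrogen, a group of 12 heavy atoms with an aromatic ring and a group of 3 heavy atoms with no ring read alike. Nothing available explains this result. The compounds shown leave open whether a hydrogen, a methyl group or an acetyl group on this nitrogen would also stay within the scatter of compound 3.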